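The source may hold more compounds than are shown below. What is called first, only, known or untested is meant among the compounds shown, and "the series" means these compounds.

In a functional assay on Dorsal root ganglion for antagonist activity at transient receptor potential cation channel subfamily V member 1 (Rattus norvegicus) (on this read-out lower numbers stand for stronger inhibition and higher numbers for weaker inhibition), compound 1 `CC(C)(C)c1ccc(NC(=O)c2ccc(-c3ccccn3)cc2)cc1` gives 31 nM. In this assay compound 3 `Cc1cccnc1-c1ccc(C(=O)Nc2ccc(C(C)(C)C)cc2)cc1` gives 31 nM, and compound 2 `CC(C)(C)c1ccc(NC(=O)c2ccc(-c3cnccn3)cc2)cc1` gives 1000 nM. Compound 1 therefore stands level with compound 3, the two together giving the lowest numbers of the three, while compound 2 sits far higher. Both measured steps concern the outer ring on the carbonyl side of the shared core: a 32-fold higher number from compound 1 to compound 2 (1.51 log units; beyond the scatter), whereas no change at the digits printed from compound 1 to compound 3 (within the scatter). Compound 4 `Cc1ccc(NC(=O)c2ccc(-c3ccccn3)cc2)cc1` differs from compound 1 at the opposite end of the shared core: methyl in place of tert-butyl on an aromatic carbon. Going by the values given here, no measured step touches this place, so there is no direct guide to the size of the change. The known steps show only that one end of the shared core can move the number a great deal while a small addition at that same end leaves it unchanged. On that basis compound 4 is expected to give a higher number, estimated at 500 nM with a range from 100 nM to 3000 nM. The expected step is a 16-fold higher number from compound 1 to compound 4 (1.21 log units; beyond the scatter).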

Compound 4, half-maximal inhibitory concentration: 2300 nM
Beside the measured number, compound 4's estimate is 4.6-fold (0.66 log units) below it, and the stated range covers the measured number.
By their numbers in this assay, from the lowest: compounds 1 and 3 (each within the scatter of the next); then compound 2; then compound 4.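

In this assay, going by these compounds alone, methyl in place of tert-butyl gives a 74-fold higher number from compound 1 to compound 4 (1.87 log units; beyond the scatter), the first sign that this place, para to a large group, also strongly affects the number, as the earlier steps changed a different place. Both groups contain carbon only, with no ring, no hydrogen-bond donors or acceptors and no net charge, so a swap between two plain carbon groups is enough to produce a large step. Nothing measured here explains why the number rises so far.

With only tert-butyl and methyl shown at this place, it remains open how the number behaves with an intermediate carbon group such as isopropyl, or with groups containing other atoms, such as trifluoromethyl or an amine. On these data alone, it is also open whether the same swap would give a step of similar size with pyrazin-2-yl or 3-methylpyridin-2-yl in place of pyridin-2-yl.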